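Working notes: the step from compound 3 to compound 4

This account rests on a few compounds, and the source may have more. Where it says the series, first, only, none or still open, it means among the compounds named here.

compound 1 `CC(C)C(NC(=O)NO)C(=O)NC1CCCCC1` — in a functional assay on WI-38 cells (Homo sapiens) for inhibition; a lower number here means a stronger inhibitor, a higher number a weaker inhibitor: 58800 nM
compound 2 `CCC(C)C(NC(=O)NO)C(=O)NC1CCCCC1` — this assay: > 100000 nM, a limit of the assay and not a number
compound 3 `CC(C)C(NC(=O)NO)C(=O)NC1CCCC1` — this assay: > 100000 nM, a limit of the assay and not a number

From the compounds shown here alone, compound 3 stands at the limit of this assay, so its own number is unknown; only compound 1 gives a number in the set. Compound 4 `CCC(C)C(NC(=O)NO)C(=O)NC1CCCC1` differs from compound 3 by methyl in place of hydrogen on a saturated chain carbon, three bonds along the chain from an amide-type nitrogen and a carbonyl carbon. The same change has been measured once: an at least 1.7-fold higher number from compound 1 to compound 2 (0.23 log units; that floor lies within the scatter). The other measured step, an at least 1.7-fold higher number from compound 1 to compound 3 (0.23 log units; that floor lies within the scatter), leads to compound 3 itself. Both steps end at the limit of > 100000 nM in this assay, at which 2 of the 3 values shown sit, so their true size is not fixed, but neither shows any lower number. With compound 3 already at the limit, the expected step is a step that the limit leaves unreadable from compound 3 to compound 4, most likely again reported only as a limit. Compound 4 is estimated at 200000 nM, range 100000 nM to 600000 nM.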

Compound 4, half-maximal inhibitory concentration: > 100000 nM
Compound 4 ended at the assay's limit; the forecaster's own chance of this, stated with the estimate: 90%; the middle value does not contradict the limit.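

No new step can be read from compound 4 to compound 3 or compound 2, as all three sit at a limit and not at a number: the limit of > 100000 nM in this assay, at which 3 of the 4 values shown sit.

The compounds shown leave open how far compound 2, compound 3 and compound 4 actually lie from one another.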